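The compounds below may be only part of what the source reports. "The series", "measured", "known", "first", "only" and "open" are said of these compounds alone.

Measured so far:
compound 1 `C=C1[C@@H](O)[C@H](n2cnc3c(OC)nc(N)nc32)O[C@@H]1CO`: 446000 nM
compound 2 `C=C1[C@H](n2cnc3c(O)nc(N)nc32)O[C@H](CO)[C@H]1O`: 8500 nM

In a functional assay on L1210 cells (Mus musculus) for inhibition (a higher number here means a weaker inhibitor, a lower number a stronger inhibitor), compound 2 holds the lower of the two numbers, and its gap to compound 1 lies beyond the scatter. For the measured compounds named here, no measured pair differs in one place only, so the next change has no direct precedent.

Compound 3 `C=C1[C@H](n2cnc3c(SC)nc(N)nc32)O[C@H](CO)[C@H]1O` carries methylsulfanyl in place of hydroxy on an aromatic carbon next to the ring nitrogen (methylsulfanyl in place of hydroxy on an aromatic carbon). A step beyond the scatter is expected in this assay towards a higher number, though compound 3 is expected to remain a stronger inhibitor than compound 1, which gives 446000 nM. The estimate amounts to a 3.5-fold higher number from compound 2 to compound 3 (0.55 log units; beyond the scatter) in the direction of weaker inhibition. For compound 3 the estimated value is 30000 nM (range 6000 nM to 150000 nM).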

Compound 3, half-maximal inhibitory concentration: > 500000 nM
Compound 3 ended at the assay's limit (the forecaster's own chance of this, stated with the estimate: 10%); middle value at least 16-fold (1.22 log units) from the limit.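

In this assay, for the compounds shown here, putting methylsulfanyl in place of hydroxy on this aromatic carbon gives an at least 58-fold higher number from compound 2 to compound 3 (1.76 log units; beyond the scatter), the first comparison between compounds that differ in one place. At this position the hydroxy of compound 2 is therefore clearly preferred over methylsulfanyl. Compound 3 gives > 500000 nM, which is a limit of the assay and not a number, so the full size of the step cannot be read: the limit of > 500000 nM in this assay, at which 1 of the 3 values shown sits.

Going by these compounds alone, the single step does not separate the loss of the hydroxy from the arrival of the sulfur or its methyl. An amine or a thiol on the same aromatic carbon would help to tell these apart, and a longer chain on the sulfur would not settle the question without them.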